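The source may hold more compounds than are shown below. What is called first, only, known or untested is meant among the compounds shown, and "the series" means these compounds.

Measured in an ADME assay on NIH3T3 cells (Mus musculus) for cytotoxicity, read by MTT assay, with a stated time of 72 h; a lower number here means a stronger inhibitor, a higher number a weaker inhibitor:
compound 1 `COc1ccc(/C=C/c2cc(C)no2)cc1OC`: 93200 nM
compound 2 `Cc1cc(/C=C/c2ccc(O)c(O)c2)on1`: 26200 nM
compound 3 `Cc1cc(/C=C/c2ccc(O)cc2)on1`: 88500 nM

In this assay, compound 3 lies within the scatter of compound 1 and beyond the scatter above compound 2. The next compound, compound 4 `COc1cc(/C=C/c2cc(C)no2)ccc1O`, differs from compound 3 by methoxy in place of hydrogen on an aromatic carbon, ortho to a hydroxy group.

Among the compounds with values here, one measured step touches this place on the ring: a 3.4-fold higher number from compound 2 to compound 3 (0.53 log units; beyond the scatter), a modest step in which hydrogen replaces hydroxy. It concerns hydroxy, however, not methoxy. Compound 1 carries methoxy at this place and a second methoxy where compound 3 has its hydroxy. Compound 1 gives 93200 nM, within the scatter of compound 3. The evidence therefore points to a smaller change than the measured step, perhaps slightly towards a lower number, and possibly none beyond the scatter. The expected change is a 1.4-fold lower number from compound 3 to compound 4 (0.13 log units; within the scatter). For compound 4 the estimated value is 65000 nM, with an expected range of 30000 nM to 120000 nM.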

Compound 4, half-maximal inhibitory concentration: > 100000 nM
Compound 4 gave a limit, no number; the forecaster's own chance of this, stated with the estimate: 10%; middle value at least 1.5-fold (0.18 log units) away from the limit.
By their numbers in this assay, from the lowest: compound 2; then compounds 3 and 1 (each within the scatter of the next). At a limit, above all of these: compound 4.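

In this assay compound 4 gives > 100000 nM, a limit of the assay and not a number. The earlier compounds shown here showed only that hydroxy at this place, ortho to a hydroxy group, gives a lower number than hydrogen; the new result shows that methoxy there does not keep this lower number, with methyl on that oxygen giving an at least 3.8-fold higher number from compound 2 to compound 4 (0.58 log units; beyond the scatter). The other two steps, an at least 1.1-fold higher number from compound 3 to compound 4 (0.05 log units; that floor lies within the scatter) and an at least 1.0-fold higher number from compound 1 to compound 4 (0.03 log units; that floor lies within the scatter), have floors within the scatter, and their full size cannot be read because compound 4 stands at a limit: the limit of > 100000 nM in this assay, at which 1 of the 4 values shown sits.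

Going by these compounds, what an amine or a fluorine at this place would do remains open. So does the effect of a longer chain on that oxygen, such as ethoxy.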